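The compounds below may be only part of what the source reports. "The series", "measured", "known", "first", "only" and "open" are said of these compounds alone.

In a functional assay on HeLa cells (Homo sapiens) for antiproliferative activity, read by MTT assay, with a stated time of 72 h (on this read-out lower numbers stand for stronger inhibition and higher numbers for weaker inhibition), the measured compounds are:
compound 1, `CCCCCc1ccc(C#Cc2c(-c3ccc(CCCCC)cc3)oc3nc(=O)n(Cc4cn(-c5ccc(Cl)cc5)nn4)cc23)cc1`, which gives > 100000 nM, a limit of the assay rather than a number.
compound 2, `CCCCCc1ccc(C#Cc2c(-c3ccc(CCCCC)cc3)oc3nc(=O)n(Cc4cn(Cc5ccccc5)nn4)cc23)cc1`, which gives 73000 nM.
compound 3, `O=c1nc2oc(C3CC3)cc2cn1Cc1cn(-c2ccc(Cl)cc2)nn1`, which gives > 100000 nM, again a limit of the assay.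

Compound 1 and compound 2 share one core and differ in a single place: benzyl in place of 4-chlorophenyl on an aromatic nitrogen. That change produced an at least 1.3-fold lower number from compound 1 to compound 2 (0.13 log units; that floor lies within the scatter), so the two values cannot be told apart with confidence. Compound 3 is built on a different core; the difference between the two cores is not broken down here. It is worth noting (the limit of > 100000 nM in this assay, at which 2 of the 3 values shown sit).

Compound 4, `O=c1nc2oc(C3CC3)cc2cn1Cc1cn(Cc2ccccc2)nn1`, has not been measured. It stands to compound 3 exactly as compound 2 stands to compound 1: benzyl in place of 4-chlorophenyl on an aromatic nitrogen, the same change at the same place. Since the matching step an at least 1.3-fold lower number from compound 1 to compound 2 (0.13 log units; that floor lies within the scatter) stayed within the scatter, little movement is expected here either. Compound 4 is therefore expected to show a number no higher from compound 3 to compound 4 (the limit leaves the size open). Compound 4 is estimated at 100000 nM in this assay, most plausibly between 50000 nM and 250000 nM, with a fair chance of another limit.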

Compound 4, half-maximal inhibitory concentration: 50000 nM
Beside the measured number, compound 4's estimate is 2.0-fold (0.30 log units) above it; low and high end bracket the measured number.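

In this assay, putting benzyl in place of 4-chlorophenyl on an aromatic nitrogen of the core of compound 3 gives an at least 2.0-fold lower number from compound 3 to compound 4 (0.30 log units; that floor lies within the scatter). Each of the two cores therefore shows a floor for this change that stays within the scatter, so nothing here speaks against the change carrying over from one core to the other, but nothing proves that it does: the same change on two cores in this assay, an at least 1.3-fold lower number (0.13 log units; that floor lies within the scatter) from compound 1 to compound 2 and an at least 2.0-fold lower number (0.30 log units; that floor lies within the scatter) from compound 3 to compound 4; the limit leaves it open whether they differ The true size of the step is unknown on either core, since one compound of each pair gives only a limit, not a number: the limit of > 100000 nM in this assay, at which 2 of the 4 values shown sit.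

The compounds shown leave open how other groups on that aromatic nitrogen would behave, for example a longer alkyl chain, or a benzyl carrying an amine or a carboxylic acid. Also open, as far as these compounds go, is whether any such group would give a number clearly lower than those of compound 2 and compound 4, which would make a comparison between the cores possible.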